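This account rests on a few compounds, and the source may have more. Where it says the series, first, only, none or still open, it means among the compounds named here.

The series shares one terpene-derived core. Compound 1 `C=C1CCC[C@H]2[C@](C)(CCC(C)=O)[C@@H](C)CC[C@]12C` carries a side chain without the cyclic peroxide. In a functional assay on HCC 2998 cells (Homo sapiens) for inhibition (a higher number here means a weaker inhibitor of growth, a lower number a stronger inhibitor of growth), compound 1 returns only a limit rather than a number, > 15000 nM, which corresponds to the limit of > 15000 nM in this assay, at which 1 of the 3 values shown sits. Compound 2 `C=C1CCCC(C)(C)C1CC[C@]1(C)CC[C@H]([C@@H](C)C(=O)OC)OO1` holds the peroxide ring and a methyl ester; in this assay compound 2 gives 3680 nM. Compound 3 `C=C1CCCC(C)(C)C1CC[C@@]1(C)CC[C@H]([C@@H](C)C(=O)O)OO1` is the free acid of the same peroxide; in this assay compound 3 gives 6780 nM. Among the two numbers shown, compound 3 has the higher one, but its gap to compound 2 lies within the usual scatter, so no order between the two can be claimed.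

Compound 4 `C=C1CCCC(C)(C)C1CC[C@]1(C)CC[C@@H]([C@@H](C)C(=O)O)OO1` differs from compound 3 only in configuration: the two compounds have the same atoms and bonds; at least one stereo element is drawn with a configuration in one of them and without one in the other: 2 of 4 stereo elements differ; a stereocentre at a saturated ring carbon is drawn S in compound 3 and R in compound 4; a stereocentre at a saturated ring carbon is drawn R in compound 3 and S in compound 4. Going by the values given here, no measured pair tells how such an inversion of two ring stereocentres moves the read-out in this assay, so the expected step from compound 3 to compound 4 is small and of uncertain direction, a 1.0-fold higher number from compound 3 to compound 4 (0.01 log units; within the scatter). Compound 4 is therefore expected to give about 7000 nM in this assay, within 2500 nM to 20000 nM.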

Compound 4, concentration for 50% growth inhibition: > 10000 nM
Compound 4: only a limit was reported; the forecaster's own chance of this, stated with the estimate: 15%; at least 1.4-fold (0.15 log units) between middle value and limit.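

Going by these compounds alone, the earlier compounds offered no pair differing in one place, so compounds 3 and 4 give the first reading of what inverting the two ring stereocentres does while atoms and bonds stay the same. Compound 4 returns only a limit, so the pair gives an at least 1.4-fold higher number from compound 3 to compound 4 (0.16 log units; that floor lies within the scatter) and no exact size for the step. As that floor lies within the scatter, the pair does not establish that this inversion changes growth inhibition, and the reading carries one further qualification: the fact that one of compounds 3 and 4 is drawn with a defined configuration and the other without, at the place where they differ

The compounds shown leave open what number compound 4 would give and whether the same inversion would act alike on the methyl ester of compound 2. They also leave open how an amide or a primary alcohol would read in place of the carboxylic acid in either configuration.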